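Swapping a trifluoromethylphenyl for a hydroxy-methoxyphenyl

A few compounds are considered here, and "the series" means these few. Any claim that something is new, unique, unknown or untested is made for them only; others in the source may bear on it.

Compound 1 `COc1cc(-n2cnc3ccc(-c4ccc(C(F)(F)F)cc4)cc32)cc(OC)c1OC` is the starting point. In a functional assay on SGC-7901 cells (Homo sapiens) for antiproliferative activity, read by MTT assay, with a stated time of 72 h (on this read-out higher numbers stand for weaker inhibition and lower numbers for stronger inhibition), compound 1 gives 890 nM, the lowest of the two numbers reported. Compound 2 `COc1cc(-n2cnc3ccc(-c4ccc(Cl)cc4)cc32)cc(OC)c1OC` gives 1270 nM, and a 1.4-fold higher number from compound 1 to compound 2 (0.15 log units; within the scatter). Compound 3 `COc1cc(-n2cnc3ccc(-c4ccccc4Cl)cc32)cc(OC)c1OC` reaches only a limit of the assay, > 10000 nM, marked by the limit of > 10000 nM in this assay, at which 1 of the 3 values shown sits. Even so, an at least 11-fold higher number from compound 1 to compound 3 (1.05 log units; beyond the scatter) and an at least 7.8-fold higher number from compound 2 to compound 3 (0.89 log units; beyond the scatter), showing that moving the chloro on the phenyl group changes the value strongly. Compound 4 `COc1ccc(-c2ccc3ncn(-c4cc(OC)c(OC)c(OC)c4)c3c2)cc1O` is not yet measured. It differs from compound 1 in one place: 3-hydroxy-4-methoxyphenyl in place of 4-(trifluoromethyl)phenyl on an aromatic carbon. Among the compounds with values here, no measured step exchanges a group of this kind, so the estimate leans on compound 1 at 890 nM with a wide range. Compound 4 is therefore expected at 600 nM, between 100 nM and 4000 nM, meaning a 1.5-fold lower number from compound 1 to compound 4 (0.17 log units; within the scatter).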

Compound 4, half-maximal inhibitory concentration: 44 nM
Beside the measured number, compound 4's estimate is 14-fold (1.13 log units) above it; measured number below the stated range.
By their numbers in this assay, from the lowest: compound 4; then compounds 1 and 2 (each within the scatter of the next). At a limit, above all of these: compound 3.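

In this assay, the group on this aromatic carbon can matter far more than the chloro and trifluoromethyl compounds suggested: 3-hydroxy-4-methoxyphenyl gives a 20-fold lower number from compound 1 to compound 4 (1.31 log units; beyond the scatter) and a 29-fold lower number from compound 2 to compound 4 (1.46 log units; beyond the scatter). Unlike the groups before it, this one brings a hydrogen-bond donor and hydrogen-bond acceptors. The widest step, an at least 220-fold lower number from compound 3 to compound 4 (2.35 log units; beyond the scatter), starts from a limit and not a number: the limit of > 10000 nM in this assay, at which 1 of the 4 values shown sits.

The compounds shown do not separate the part played by the hydroxy from that of the methoxy. Going by these compounds, whether an amine or a carboxylic acid in place of the hydroxy would hold this gain also stays open.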